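Swapping the dimethoxyphenyl for chlorophenyl on a pyrimidinone core

The source may report more compounds than this note shows. Statements on the series, on what has been measured and on what is new or still open speak of the compounds shown alone.

Measured compounds:
- compound 1, `Cc1nc(-c2ccccc2)sc1C(=O)CSc1nc(-c2ccc(Cl)c(Cl)c2)c(C#N)c(=O)[nH]1`: 75.3%
- compound 2, `Cc1nc(-c2ccccc2)sc1C(=O)CSc1nc(-c2ccccc2)c(C#N)c(=O)[nH]1`: 77.5%
- compound 3, `COc1ccc(-c2nc(SCC(=O)c3sc(-c4ccccc4)nc3C)[nH]c(=O)c2C#N)cc1OC`: 21.4%

The three measured compounds share one core and differ only in the aryl group on the six-membered ring that carries two nitrogens. In a functional assay on U-87MG ATCC cells for antiproliferative activity against U-87 MG (Homo sapiens), read by MTT assay, with a stated time of 48 h, tested at 50 uM (on this read-out lower numbers stand for a stronger effect and higher numbers for a weaker effect at the one concentration tested), compound 3 gives 21.4%, the lowest of the three numbers and so the strongest effect seen here; compound 1 and compound 2 both sit far higher, with a number 53.9 percentage points lower from compound 1 to compound 3 (beyond the scatter) and a number 56.1 percentage points lower from compound 2 to compound 3 (beyond the scatter). The step between compound 1 and compound 2 is small, a number 2.2 percentage points higher from compound 1 to compound 2 (within the scatter).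

Compound 4, `Cc1nc(-c2ccccc2)sc1C(=O)CSc1nc(-c2ccc(Cl)cc2)c(C#N)c(=O)[nH]1`, is not yet measured. It differs from compound 3 by 4-chlorophenyl in place of 3,4-dimethoxyphenyl on an aromatic carbon. Both measured steps toward the 3,4-dimethoxyphenyl were large drops; a 4-chlorophenyl resembles the plain phenyl of compound 2 and the 3,4-dichlorophenyl of compound 1 more than the dimethoxyphenyl. A large rise is therefore expected, a number 52.6 percentage points higher from compound 3 to compound 4 (beyond the scatter), because of a number 56.1 percentage points lower from compound 2 to compound 3 (beyond the scatter) and a number 53.9 percentage points lower from compound 1 to compound 3 (beyond the scatter) running the other way. Compound 4 is estimated at 74%, within 58% to 88%.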

Compound 4, a percentage reported as activity, at one concentration (the size of the read-out at that concentration, not a potency): 63.4%
The estimate for compound 4 lay 10.6 percentage points above the measured number; the range from low to high includes it.
By their numbers in this assay, from the lowest: compound 3; then compound 4; then compounds 1 and 2 (each within the scatter of the next).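

Adding one chloro group to the plain phenyl gives a number 14.1 percentage points lower from compound 2 to compound 4 (beyond the scatter), and taking one chloro group away from the 3,4-dichlorophenyl gives a number 11.9 percentage points lower from compound 1 to compound 4 (beyond the scatter). Chlorine at this position therefore does not act in simple steps: the single chloro of the 4-chlorophenyl gives a stronger effect than either no chloro group or two. That gain is still small beside a number 42 percentage points higher from compound 3 to compound 4 (beyond the scatter), so the 3,4-dimethoxyphenyl keeps a wide lead over all three other aryl groups.

Nothing available here gives a reason for these steps. As far as these compounds go, whether the lead of compound 3 needs both methoxy groups remains open, as does how a phenyl carrying a single methoxy group or an amine would compare.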